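Chloro to cyano exchange: solubility expectation for compound 3

The compounds below may be only part of what the source reports. "The series", "measured", "known", "first", "only" and "open" are said of these compounds alone.

The series is read in a physicochemical assay for solubility, read by nephelometry, at pH 6.5; a lower number here means a less soluble compound, a higher number a more soluble compound. Compound 1 `N#Cc1cnc(NC(=O)N2CCN(c3ccc(Cl)c(Cl)c3)CC2)s1` gives in this assay only a limit, < 1600 nM. Compound 2 `O=C(Nc1ncc(Cl)s1)N1CCN(c2cnc(Cl)c(Cl)c2)CC1` likewise gives in this assay only a limit, < 1600 nM. Going by the values given here, compound 2 thus stands where every value so far stands, at the limit of < 1600 nM in this assay, at which 2 of the 2 values shown sit, and no step between measured compounds is available. Compound 3 `N#Cc1cnc(NC(=O)N2CCN(c3cnc(Cl)c(Cl)c3)CC2)s1` differs from compound 2 by cyano in place of chloro on an aromatic carbon, with 5-chloro-1,3-thiazol-2-yl becoming 5-cyano-1,3-thiazol-2-yl. Among the compounds with values here, no measured step gives a direction for this change. Since the two values shown both sit at the limit of < 1600 nM in this assay, at which 2 of the 2 values shown sit, compound 3 is expected to report the same limit rather than a number. The expected step from compound 2 to compound 3 in this assay is a step that the limit leaves unreadable from compound 2 to compound 3, none beyond the scatter. Compound 3 is estimated in this assay at 1000 nM, with a range from 300 nM to 2500 nM.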

Compound 3, solubility: < 1600 nM
Compound 3 was reported as a limit; the forecaster's own chance of this, stated with the estimate: 70%; the middle value does not contradict the limit.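

Going by these compounds alone, compound 1, compound 2 and compound 3 all report the same limit in this assay, so no step among them can be read. From the compounds shown here alone, whether cyano in place of chloro on an aromatic carbon, or 5,6-dichloropyridin-3-yl in place of 3,4-dichlorophenyl, changes solubility in either direction stays open.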